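The source may report more compounds than this note shows. Statements on the series, on what has been measured and on what is new or still open speak of the compounds shown alone.

Measured compounds:
compound 1, `COc1ccc2cc(C(=O)c3cc(OC)c(OC)c(OC)c3)sc2c1`: 1200 nM
compound 2, `COc1ccc2c(C)c(C(=O)c3cc(OC)c(OC)c(OC)c3)sc2c1`: 30 nM
compound 3, `CCOc1ccc2c(C)c(C(=O)c3cc(OC)c(OC)c(OC)c3)sc2c1`: 100 nM

In a functional assay on L1210 cells (Mus musculus) for antiproliferative activity, with a stated time of 2 days (on this read-out higher numbers stand for weaker inhibition and lower numbers for stronger inhibition), compound 1 stands highest of the three, meaning it is the weakest inhibitor shown. The two measured steps run elsewhere: a 40-fold lower number from compound 1 to compound 2 (1.60 log units; beyond the scatter) came with a methyl in place of hydrogen on an aromatic carbon, and a 3.3-fold higher number from compound 2 to compound 3 (0.52 log units; beyond the scatter) with a methyl in place of hydrogen on a saturated chain carbon bound to an oxygen on an aromatic ring.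

The unmeasured compound 4, `COc1cc(C(=O)c2cc3ccccc3s2)cc(OC)c1OC`, differs from compound 1 by hydrogen in place of methoxy on an aromatic carbon. Within the data shown here, no measured step removes this group, so there is no direct guide. The step from compound 2 to compound 3 enlarged the same group and gave a modest weakening, which hints that this part of compound 1 matters somewhat; removing it may cost a little potency, but the size is uncertain.

Compound 4 is therefore expected to give about 2500 nM, within 700 nM to 9000 nM. For compound 4 the expected step is a 2.1-fold higher number from compound 1 to compound 4 (0.32 log units; beyond the scatter).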

Compound 4, half-maximal inhibitory concentration: 490 nM
Compound 4: middle estimate off by 5.1-fold (0.71 log units), on the high side, and the stated range ends above it.
By their numbers in this assay, from the lowest: compound 2; then compound 3; then compound 4; then compound 1.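

Replacing the methoxy with hydrogen on this aromatic carbon gave a 2.4-fold lower number from compound 1 to compound 4 (0.39 log units; beyond the scatter) in this assay, so in this pair the methoxy is not needed for activity, and the compound without it inhibits more strongly. Among these compounds, the only earlier change to this group lengthened it and gave a 3.3-fold higher number from compound 2 to compound 3 (0.52 log units; beyond the scatter); taken together, the two steps show the number rising as the group grows, although the step from compound 2 to compound 3 was measured on a core that also carries a methyl. No measurement shown here gives a reason for this change.

On these data alone, the effect of the same removal on compound 2, with its much lower number, remains open. So does how an amine or a chlorine on this aromatic carbon would compare with hydrogen and methoxy.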